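Thioamide Methyl Removal: Compound 3 to Compound 4

The compounds below may be only part of what the source reports. "The series", "measured", "known", "first", "only" and "open" are said of these compounds alone.

Compound 1 `Cc1ccc(C2=NN(C(N)=S)CC2)cc1` gives "not active" (no number reported) in an in vitro assay on cells for inhibition of Amine oxidase [flavin-containing] A (Homo sapiens), read by Amplex Red, with a stated time of 15 min, tested at 100 uM; a higher number here means more inhibition at the concentration tested (going by the name of the read-out), a lower number less inhibition. Compound 2 `COc1ccc(C2=NN(C(N)=S)CC2C)cc1` gives 40%. Compound 3 `CNC(=S)N1CC(C)C(c2ccc(C)cc2)=N1` gives 40%.

Compound 3 stands level with compound 2 at the digits reported, within the usual scatter of this assay, while compound 1 returned no number. Compound 4 `Cc1ccc(C2=NN(C(N)=S)CC2C)cc1` differs from compound 3 in one place: hydrogen in place of methyl on an amide-type nitrogen. Going by the values given here, no measured pair shows this change on its own, so its effect is not known here. Compound 1, which shares the hydrogen on that nitrogen with compound 4, was reported as not active, which argues against a gain. A step from compound 3 to compound 4 of a number 10 percentage points lower from compound 3 to compound 4 (within the scatter) is expected, downward but within or just beyond the scatter. Compound 4 is estimated at 30%, between 5% and 55%.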

Compound 4, a percentage reported as inhibition, at one concentration (the size of the read-out at that concentration, not a potency): "not active" (no number reported)
Compound 4 has no reported number here; no gap can be computed for the estimate.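

In this assay, going by these compounds alone, compound 4 gives "not active" (no number reported), so no step from compound 3 can be read, and no evidence bears on this result. The compounds shown leave open what size of effect methylamino to amino has on inhibition.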